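Amino in place of hydrogen on a chloropurine core

A few compounds are considered here, and "the series" means these few. Any claim that something is new, unique, unknown or untested is made for them only; others in the source may bear on it.

Measured compounds:
compound 1 `ClCc1ccccc1Cn1cnc2c(Cl)nc(Cl)nc21` with 580 nM
compound 2 `ClCc1ccccc1Cn1cnc2c(Cl)ncnc21` with 1820 nM

Compound 2 gives the highest of the two numbers in a functional assay on NCI-H522 cells (Homo sapiens) for cytotoxicity, read by sulforhodamine B assay, with a stated time of 48 h (a lower number here means a stronger inhibitor of growth, a higher number a weaker inhibitor of growth), with compound 1 nearest and a 3.1-fold higher number from compound 1 to compound 2 (0.50 log units; beyond the scatter) between them. The unmeasured compound 3 `Nc1nc(Cl)c2ncn(Cc3ccccc3CCl)c2n1` differs from compound 2 by amino in place of hydrogen on an aromatic carbon. Going by the values given here, the only measured step, the replacement of chloro by hydrogen at the same place, shifted the number in this assay by a 3.1-fold higher number from compound 1 to compound 2 (0.50 log units; beyond the scatter); no measured pair shows what an amino group does there, so the step from hydrogen back to a heavy atom at that position is guided by that step alone and only loosely. Compound 3 is expected to sit near compound 2, with the estimated step of a 1.4-fold lower number from compound 2 to compound 3 (0.15 log units; within the scatter) most likely small and its direction uncertain. For compound 3 in this assay the estimate is 1300 nM, with a range from 350 nM to 4800 nM.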

Compound 3, concentration for 50% growth inhibition: 2950 nM
For compound 3 the middle estimate is 2.3-fold (0.36 log units) below the measured one, within the range that was stated.
By their numbers in this assay, from the lowest: compound 1; then compounds 2 and 3 (each within the scatter of the next).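

Amino in place of hydrogen on an aromatic carbon between two ring nitrogen atoms gives a 1.6-fold higher number from compound 2 to compound 3 (0.21 log units; within the scatter) in this assay and so does not set compound 3 apart from compound 2, which means that in this assay this group cannot be told from a bare hydrogen at this carbon. Amino in place of chloro at the same carbon gives a 5.1-fold higher number from compound 1 to compound 3 (0.71 log units; beyond the scatter) and this step lies beyond the scatter, so of the three groups seen there, only chloro stands apart, with the lower number. The earlier pair showed only what was lost with the chloro group, whereas these compounds show that a heavy atom at this carbon does not by itself keep the number of compound 1, since amino brings one and compound 3 still stays with compound 2.

No evidence at hand bears on why amino and chloro part in this way. As far as these compounds go, what remains open is whether the match with compound 1 belongs to chloro alone or would extend to bromo, fluoro, methyl or methoxy at this carbon, and whether a larger amine such as dimethylamino would stay with amino.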